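The source may report more compounds than this note shows. Statements on the series, on what has been measured and on what is new or still open speak of the compounds shown alone.

In a physicochemical assay for lipophilicity, using the shake flask method, measured as octanol-water partition, at pH 7.4 (a higher number here means a more lipophilic compound, a lower number a more polar compound), compound 2 `CC(=O)N[C@@H]1CCC[C@H](C(=O)Nc2cc(-c3cnn4c3OCCC4)c(Cl)cn2)C1` gives 2.6 and sits within the scatter of compound 1 `CC(=O)N[C@@H]1CCC[C@H](C(=O)Nc2cc(-c3cnn4c3CCC4)c(Cl)cn2)C1` at 2.9, while compound 3 `CC(=O)N[C@@H]1CCC[C@H](C(=O)Nc2cc(-c3cnn4c3CC(C)C4)c(Cl)cn2)C1` gives 3.4; 3.4 (2 entries) and reads higher than both.

Compound 4 `CC(=O)N[C@@H]1CCC[C@H](C(=O)Nc2cc(-c3cnc4n3CC(C)(C)C4)c(Cl)cn2)C1` differs from compound 2 by one exchange: a group of 10 heavy atoms (8 carbon, 2 nitrogen; one five-membered non-aromatic ring with 1 hetero atom, one five-membered aromatic ring with 2 hetero atoms) in place of a group of 9 heavy atoms (6 carbon, 2 nitrogen, 1 oxygen; one five-membered aromatic ring with 2 hetero atoms, one six-membered non-aromatic ring with 2 hetero atoms), on an aromatic carbon. The exchange lies on an aromatic carbon, ortho to a chloro group and opposite the ring nitrogen.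

Going by the values given here, the only measured step at this place is a number 0.30 log units lower from compound 1 to compound 2 (within the scatter). It links the ring pairing that enters here, one five-membered non-aromatic ring with 1 hetero atom and one five-membered aromatic ring with 2 hetero atoms, to the pairing that leaves, and read in reverse it offers no shift beyond the scatter. Compound 3 at 3.4; 3.4 (2 entries) carries the same ring pairing and shows that such a compound can read clearly higher than the value of compound 2. Among the compounds with values here, no measured compound carries the exact entering group, so the expectation rests on these two comparisons and stays wide.

An upward move is expected, estimated as a number 0.50 log units higher from compound 2 to compound 4 (beyond the scatter) in this assay. For compound 4 the estimated value is 3.1, with an expected range from 2.6 to 3.6.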

Compound 4, distribution coefficient: 3.6
For compound 4 the middle estimate is 0.50 log units below the measured one; low and high end bracket the measured number.
By their numbers in this assay, from the lowest: compounds 2 and 1 (each within the scatter of the next); then compound 4.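

In this assay this aromatic carbon, ortho to a chloro group and opposite the ring nitrogen, now shows a change beyond the scatter, with a number 1.00 log units higher from compound 2 to compound 4 (beyond the scatter) as the reading for the exchange of the oxygen-containing group. The same entering group also gives a number 0.70 log units higher from compound 1 to compound 4 (beyond the scatter) even though the groups of compound 1 and compound 4 both carry one five-membered non-aromatic ring with 1 hetero atom and one five-membered aromatic ring with 2 hetero atoms, so this ring pairing alone does not fix the number at this position. No measurement at hand gives a cause for either step.

The group of 10 heavy atoms in compound 4 differs from the group of 8 heavy atoms in compound 1 in both atom count and atom arrangement, and the compounds shown do not separate these two differences. As far as these compounds go, how the number responds to an amine or a carboxylic acid on the five-membered non-aromatic ring also remains open.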